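The compounds below may be only part of what the source reports. "The series", "measured", "known", "first", "only" and "open" are said of these compounds alone.

Notes on the series. Compound 3 `O=C(Nc1nc2ccc(F)cc2s1)c1cn(-c2ccccc2)nc1-c1ccc(Cl)cc1` gives 7770 nM in a functional assay on U-87MG ATCC cells for cytotoxicity against U-87 MG (Homo sapiens), read by MTT assay, with a stated time of 72 h (a higher number here means a weaker inhibitor, a lower number a stronger inhibitor), the lowest of the three numbers recorded. Within the data shown here, its nearest neighbour is compound 2 `O=C(Nc1nc2ccccc2s1)c1cn(-c2ccccc2)nc1-c1ccc(Cl)cc1`, which gives 11500 nM; the one measured step that bears on the change in question is a 1.5-fold lower number from compound 2 to compound 3 (0.17 log units; within the scatter), fluoro in place of hydrogen on an aromatic carbon. Compound 1 `COc1ccc2nc(NC(=O)c3cn(-c4ccccc4)nc3-c3ccccc3)sc2c1` gives 40600 nM, and the gap between compound 1 and compound 3 is beyond the scatter, although the two differ in two places, so no single step can be read from that pair.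

Compound 4 `COc1ccc2nc(NC(=O)c3cn(-c4ccccc4)nc3-c3ccc(Cl)cc3)sc2c1` is the next member. It differs from compound 3 by methoxy in place of fluoro on an aromatic carbon. Compound 1 carries the same methoxy on the same ring, but with an unsubstituted phenyl rather than a chlorophenyl, so its value only hints at what methoxy does at this position. Given that the fluoro step was within the scatter, the change from fluoro to methoxy is expected to be modest, with the direction uncertain. Among the measured compounds shown here, a step of a 1.7-fold higher number from compound 3 to compound 4 (0.22 log units; within the scatter) is expected, leaning toward a higher number because compound 1, the only methoxy compound, gives 40600 nM. Compound 4 is therefore estimated at 13000 nM, within 4000 nM to 45000 nM.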

Compound 4, half-maximal inhibitory concentration: 21200 nM
Compound 4: middle estimate off by 1.6-fold (0.21 log units), on the low side, within the range that was stated.
By their numbers in this assay, from the lowest: compounds 3, 2, 4 and 1 (each within the scatter of the next, the first and the last beyond it).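

In this assay, among these compounds, a 2.7-fold higher number from compound 3 to compound 4 (0.44 log units; beyond the scatter) is the only step that lies beyond the scatter, so methoxy and fluoro on this aromatic carbon of the fused system can be told apart. Neither group separates from hydrogen at the same place: a 1.8-fold higher number from compound 2 to compound 4 (0.27 log units; within the scatter) and a 1.5-fold lower number from compound 2 to compound 3 (0.17 log units; within the scatter) both stay within the scatter, so the difference appears only when the two substituted compounds are set against each other. The chloro change, read here with methoxy held constant, also gives no separable result: a 1.9-fold lower number from compound 1 to compound 4 (0.28 log units; within the scatter) lies within the scatter.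

On these data alone, it remains open whether a larger step can be reached at this place with an amine, a hydroxyl or a longer alkoxy chain such as ethoxy, and whether the chloro step stays within the scatter when the fused ring carries fluoro or hydrogen rather than methoxy. Nothing available accounts for the step between fluoro and methoxy.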